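This account rests on a few compounds, and the source may have more. Where it says the series, first, only, none or still open, it means among the compounds named here.

Compound 1 `COc1ccc(-c2nnc(N3CCN(C(=O)CN4CCN(c5ccccc5OC)CC4)CC3)nc2-c2ccc(OC)cc2)cc1` is one of two reference points here. In an ADME assay on NIH3T3 cells (Mus musculus) for cytotoxicity, read by MTT assay, with a stated time of 24 h (on this read-out lower numbers stand for stronger inhibition and higher numbers for weaker inhibition), compound 1 gives only a limit, > 821000 nM. Compound 1 therefore sits at the limit of > 821000 nM in this assay, at which 1 of the 2 values shown sits. Compound 2 `O=C(CN1CCN(c2ccccc2Cl)CC1)N1CCN(c2nnc(-c3ccc(Cl)cc3)c(-c3ccc(Cl)cc3)n2)CC1` likewise gives only a limit in this assay, namely > 803000 nM. Compound 2 thus sits at the limit of > 803000 nM in this assay, at which 1 of the 2 values shown sits, so its standing on the numbers shown is a limit and not a measured figure. Compound 3 `O=C(CN1CCN(c2ccc(Cl)cc2)CC1)N1CCN(c2nnc(-c3ccc(Cl)cc3)c(-c3ccc(Cl)cc3)n2)CC1` has not yet been measured. It differs from compound 2 by 4-chlorophenyl in place of 2-chlorophenyl on an amine nitrogen in a ring. Going by the values given here, no pair of measured compounds maps this change, so no measured step can guide it. With both values shown being limits, the expected step of a number no higher from compound 2 to compound 3 (the limit leaves the size open) is essentially none beyond the scatter in either direction. Compound 3 is therefore estimated at about 800000 nM, between 300000 nM and 1500000 nM, most probably reported again only as a limit.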

Compound 3, half-maximal inhibitory concentration: > 803000 nM
Compound 3 was reported as a limit; the forecaster's own chance of this, stated with the estimate: 85%; at least 1.0-fold (0.00 log units) between middle value and limit.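

Compound 2 and compound 3 both give only limits in this assay, so no step can be read between them. The compounds shown leave open whether 4-chlorophenyl in place of 2-chlorophenyl changes this read-out, and where either compound's actual half-maximal inhibitory concentration lies.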